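The compounds below may be only part of what the source reports. "The series", "measured", "known", "first", "only" and "open" are said of these compounds alone.

Compound 3 `CCOC(=O)C(=O)Nc1ccc(-c2nc(N)n(/C(S)=N/C)n2)cc1` has the lowest number of the three compounds measured here. In a functional assay on the whole organism for inhibition, with Rattus norvegicus as the target, at a dose of 30 mg/kg (on this read-out higher numbers stand for more inhibition at the one dose given (going by the name of the read-out) and lower numbers for less inhibition), compound 3 gives 49%, the lowest of the three numbers. Compound 1 `C/N=C(\S)n1nc(-c2ccc(C)cc2)nc1N` gives 65% in this assay and compound 2 `C/N=C(\S)n1nc(-c2ccc(C#N)cc2)nc1N` gives 87%. Compound 4 `C/N=C(\S)n1nc(-c2ccc(F)cc2)nc1N` is still to be measured; it differs from compound 3 in one place: fluoro in place of ((ethoxycarbonyl)carbonyl)amino on an aromatic carbon. Among the measured compounds shown here, two measured steps bear on this. Each puts the same ((ethoxycarbonyl)carbonyl)amino group in place of a small group and each lowers inhibition beyond the scatter: a number 16 percentage points lower from compound 1 to compound 3 (beyond the scatter) and a number 38 percentage points lower from compound 2 to compound 3 (beyond the scatter). Reversing that direction, toward the small fluoro, a rise beyond the scatter is therefore expected, with a number 19 percentage points higher from compound 3 to compound 4 (beyond the scatter). For compound 4 the estimated value is 68%, within a range from 50% to 85%.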

Compound 4, a percentage reported as inhibition, in the whole organism at one dose (the size of the read-out at that dose, not a potency): 73%
Compound 4: the middle estimate sits 5 percentage points below what was measured; low and high end bracket the measured number.
By their numbers in this assay, from the lowest: compound 3; then compounds 1 and 4 (each within the scatter of the next); then compound 2.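

At this place on the aromatic ring, fluoro gives more inhibition in this assay than the much larger ((ethoxycarbonyl)carbonyl)amino group, with a number 24 percentage points higher from compound 3 to compound 4 (beyond the scatter). Fluoro and methyl cannot be told apart, with a number 8 percentage points higher from compound 1 to compound 4 (within the scatter), whereas fluoro falls short of cyano, with a number 14 percentage points lower from compound 2 to compound 4 (beyond the scatter), so among these three small groups only cyano stands out. Nothing available here explains these differences. As far as these compounds go, whether an amine or a carboxylic acid at this place would match cyano remains open.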